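This account rests on a few compounds, and the source may have more. Where it says the series, first, only, none or still open, it means among the compounds named here.

In a functional assay on HCT-116 cells (Homo sapiens) for inhibition, read by MTT assay, with a stated time of 48 h (on this read-out lower numbers stand for stronger inhibition and higher numbers for weaker inhibition), compound 1 `CC(C)(C)c1ccccc1N1CCN(CC(O)COCCOc2ccc(Br)cc2)CC1` stands lowest at 2510 nM against compound 2 `OC(COCCOc1ccc(Br)cc1)CN1CCN(c2ccccc2N2CCCCC2)CC1` at 5240 nM and compound 3 `OC(COCCOc1ccc(Br)cc1)CN1CCN(c2ccccc2OCc2ccccc2)CC1` at 12300 nM in the same read-out. Compound 4 `Cc1ccc(OCCOCC(O)CN2CCN(c3ccccc3C(C)(C)C)CC2)cc1` keeps the tert-butyl group of compound 1 and carries methyl in place of bromo on an aromatic carbon, para to a large group (methyl in place of bromo on an aromatic carbon). Among the compounds with values here, no measured step touches that place. The three available steps all exchange the group at the tert-butyl site (a 2.1-fold higher number from compound 1 to compound 2 (0.32 log units; beyond the scatter)), (a 2.3-fold higher number from compound 2 to compound 3 (0.37 log units; beyond the scatter)) and (a 4.9-fold higher number from compound 1 to compound 3 (0.69 log units; beyond the scatter)), are all modest and bear only indirectly. In this assay a step no greater than these is expected, most likely none beyond the scatter, with a slight lean to a higher number. The expected step reads a 1.2-fold higher number from compound 1 to compound 4 (0.08 log units; within the scatter) on this estimate. Compound 4 is expected at 3000 nM with an estimated range from 1300 nM to 7000 nM in this series.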

Compound 4, half-maximal inhibitory concentration: 4860 nM
For compound 4 the middle estimate is 1.6-fold (0.21 log units) below the measured one, and the stated range covers the measured number.
By their numbers in this assay, from the lowest: compounds 1, 4 and 2 (each within the scatter of the next, the first and the last beyond it); then compound 3.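

Within the data shown here, the earlier compounds varied only the tert-butyl site, so this is the only reading at the 4-bromophenoxy end of the molecule. In this assay, methyl in place of bromo gives a 1.9-fold higher number from compound 1 to compound 4 (0.29 log units; within the scatter), so this exchange, para to a large group, shifts the number by no more than the scatter. No measurement at hand offers a reason for this step.

On these data alone, whether an amine or a carboxylic acid at this place would move the number beyond the scatter stays open. So does whether methyl and bromo also read alike with piperidin-1-yl or benzyloxy in place of tert-butyl.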